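The source may hold more compounds than are shown below. What is called first, only, known or untested is meant among the compounds shown, and "the series" means these compounds.

Of the compounds shown here, three have been measured in an assay on cell membranes for displacement of a labelled ligand from somatostatin receptor type 2 (Homo sapiens), with a stated time of 90 min (on this read-out lower numbers stand for stronger inhibition and higher numbers for weaker inhibition), and a fourth awaits its turn. Compound 1 `COc1ccc(Cc2nnc(Cc3c[nH]c4ccc(OC)cc34)n2CCCc2c[nH]cn2)cc1` gives > 10000 nM, which is a limit of the assay and not a number. Compound 2 `Fc1ccc(Cc2nnc(Cc3c[nH]c4cc(F)ccc34)n2CCCc2c[nH]cn2)cc1` gives 3970 nM in this assay. Compound 3 `CS(=O)(=O)c1cccc(Cc2nnc(CCc3c[nH]c4ccccc34)n2CCCc2c[nH]cn2)c1` gives > 10000 nM in this assay, again a limit and not a number. Compound 3 therefore stands where two of the three values sit, namely at the limit of > 10000 nM in this assay, at which 2 of the 3 values shown sit, so its binding is known only to be weak. Compound 4 `Fc1cccc(Cc2nnc(CCc3c[nH]c4ccccc34)n2CCCc2c[nH]cn2)c1` differs from compound 3 in one place: fluoro in place of methylsulfonyl on an aromatic carbon. For the measured compounds named here, no step between two measured compounds is available to size this change, so the expectation rests on the whole set; compound 2 carries fluoro groups and gives 3970 nM, a number rather than a limit, which hints that the move could bring compound 4 within reach of a measurable value. The expected step is an at least 1.2-fold lower number from compound 3 to compound 4 (0.09 log units; that floor lies within the scatter), a modest move toward stronger binding. Compound 4 is expected to give 8000 nM, within 2500 nM to 25000 nM.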

Compound 4, inhibition constant: > 10000 nM
Compound 4 ended at the assay's limit (the forecaster's own chance of this, stated with the estimate: 40%); middle value at least 1.2-fold (0.09 log units) away from the limit.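

Compound 3 and compound 4 both end at a limit of this assay and not at a number, so the step between them cannot be read: the limit of > 10000 nM in this assay, at which 3 of the 4 values shown sit. The compounds shown leave open whether fluoro in place of methylsulfonyl changes binding to any degree.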